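This account rests on a few compounds, and the source may have more. Where it says the series, first, only, none or still open, it means among the compounds named here.

In a functional assay on MDA-MB-436 cells (Homo sapiens) for antiproliferative activity, read by MTT assay, with a stated time of 48 h (a lower number here means a stronger inhibitor, a higher number a weaker inhibitor), compound 1 `CN1CCN(c2ccc(-c3cc4c(N5CCN(S(=O)(=O)/C=C/c6ccccc6)CC5)ncnc4s3)cc2)CC1` gives 8670 nM while compound 2 `CCS(=O)(=O)N1CCN(c2ncnc3sc(-c4ccc(N5CCN(C)CC5)cc4)cc23)CC1` gives 10600 nM and compound 3 `CCCNC(=O)N1CCN(c2ncnc3sc(-c4ccc(N5CCN(C)CC5)cc4)cc23)CC1` gives 12400 nM on the same shared core. Compound 3 therefore stands level with both others, as shown by a 1.2-fold higher number from compound 2 to compound 3 (0.07 log units; within the scatter) and by a 1.4-fold higher number from compound 1 to compound 3 (0.16 log units; within the scatter) on the same read-out.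

Compound 4 `COc1ccc(NC(=O)N2CCN(c3ncnc4sc(-c5ccc(N6CCN(C)CC6)cc5)cc34)CC2)cc1` differs from compound 3 in one place (4-methoxyphenyl in place of propyl on an amide-type nitrogen), with 4-methoxyphenyl in place of propyl on an amide-type nitrogen. Among the compounds with values here, no measured compound carries this group, so the evidence is indirect. The closest exchange of a group bearing an aromatic ring and a short chain lies on a sulfonyl sulfur elsewhere in the series, and it amounts to a 1.2-fold higher number from compound 1 to compound 2 (0.09 log units; within the scatter) in the measured direction. None of the three steps leaves the scatter, and no step beyond the scatter is expected in this assay for this change either. The expected change is a 1.2-fold lower number from compound 3 to compound 4 (0.09 log units; within the scatter) on this estimate. Compound 4 is estimated at 10000 nM (expected range 4500 nM to 22000 nM).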

Compound 4, half-maximal inhibitory concentration: 30100 nM
Beside the measured number, compound 4's estimate is 3.0-fold (0.48 log units) below it, and the stated range ends below it.
By their numbers in this assay, from the lowest: compounds 1, 2 and 3 (each within the scatter of the next); then compound 4.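

In this assay, within the data shown here, the exchanges among the earlier compounds all stayed within the scatter, so they gave no sign that the group on this side of the shared core matters. Putting 4-methoxyphenyl in place of propyl on the amide-type nitrogen gives a 2.4-fold higher number from compound 3 to compound 4 (0.39 log units; beyond the scatter), which shows that this position does respond to its substituent, in the direction of a weaker inhibitor. The gap also holds against the sulfonyl compounds, with a 2.8-fold higher number from compound 2 to compound 4 (0.45 log units; beyond the scatter) and a 3.5-fold higher number from compound 1 to compound 4 (0.54 log units; beyond the scatter), though nothing shown explains the change.

The compounds shown leave open whether the aromatic ring or its methoxy group accounts for the step, which an unsubstituted phenyl or a benzyl on the same nitrogen could separate. They also leave open how a longer alkyl chain or a chain ending in an amine would behave there.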